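The compounds below may be only part of what the source reports. "The series", "measured", "known", "first", "only" and "open" are said of these compounds alone.

The measured compounds:

Compound 1, `CNC(=O)c1cc(Oc2ccc3cc(C(=O)OC)sc3c2)ccn1`. In an ADME assay on H1-HeLa cells (Homo sapiens) for cytotoxicity, read by MTT assay, with a stated time of 3 days (a higher number here means that more compound is tolerated, a lower number that less compound is tolerated), compound 1 gives > 100000 nM, which is a limit of the assay and not a number.
Compound 2, `CNC(=O)c1cc(Oc2ccc3c(C)c(C(=O)OC)sc3c2)ccn1`. In this assay compound 2 gives 10800 nM.
Compound 3, `CCOC(=O)c1cc2ccc(OC)cc2s1`. In this assay compound 3 gives 70900 nM.

Compound 4, `CCOC(=O)c1sc2cc(OC)ccc2c1C`, has not yet been measured. The change from compound 1 to compound 2 is methyl in place of hydrogen on an aromatic carbon. It brought an at least 9.2-fold lower number from compound 1 to compound 2 (0.96 log units; beyond the scatter), and since compound 1 sits at the limit of > 100000 nM in this assay, at which 1 of the 3 values shown sits, the full size of that step is not known. The change from compound 3 to compound 4 is methyl in place of hydrogen on an aromatic carbon. This is the same kind of change, though not the same: in compound 4 the methyl is next to the ring atom that bears an ethoxycarbonyl group, while in compound 2 it is next to the ring atom that bears a methoxycarbonyl group. How the core of compound 1 and the core of compound 3 differ is not broken down here.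

Compound 4 is expected to move by about a 7.9-fold lower number from compound 3 to compound 4 (0.90 log units; beyond the scatter) in this assay, because an at least 9.2-fold lower number from compound 1 to compound 2 (0.96 log units; beyond the scatter) was seen for the same kind of change. The estimate for compound 4 in this assay is 9000 nM, with a range from 2500 nM to 40000 nM.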

Compound 4, half-maximal cytotoxic concentration: > 100000 nM
Compound 4 was reported as a limit; the forecaster's own chance of this, stated with the estimate: 5%; middle value at least 11-fold (1.04 log units) away from the limit.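

In this assay compound 4 gives > 100000 nM, which is a limit of the assay and not a number. Putting methyl in place of hydrogen gave an at least 1.4-fold higher number from compound 3 to compound 4 (0.14 log units; that floor lies within the scatter), so the fall in the number seen on the core of compound 1 did not carry over to the core of compound 3: the same change on two cores in this assay, an at least 9.2-fold lower number (0.96 log units; beyond the scatter) from compound 1 to compound 2 and an at least 1.4-fold higher number (0.14 log units; that floor lies within the scatter) from compound 3 to compound 4, at least 13-fold (1.11 log units) apart, beyond the scatter of two such steps. This does not show that the methyl raises the number on the core of compound 3, how large either step really is, or which difference between the two cores lies behind the contrast, and the top of the measurable range hides the full size of both steps: the limit of > 100000 nM in this assay, at which 2 of the 4 values shown sit.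

The compounds shown leave open what a longer chain, such as ethyl, would do in place of the methyl on either core. They also leave open whether a carboxylic acid in place of the ethoxycarbonyl group of compound 3 would change how the methyl behaves.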